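A few compounds are considered here, and "the series" means these few. Any claim that something is new, unique, unknown or untested is made for them only; others in the source may bear on it.

Measured compounds:
- compound 1 `Nc1ccccc1NC(=O)c1ccc(CSC(=S)N2CCN(c3ccc(Cl)cc3)CC2)cc1`: 32.2% in a functional assay on A-375 cells (Homo sapiens) for antiproliferative activity, read by CCK-8 assay, with a stated time of 72 h, tested at 2 uM; on this read-out lower numbers stand for a weaker effect and higher numbers for a stronger effect at the one concentration tested
- compound 2 `Nc1ccccc1NC(=O)c1ccc(CSC(=S)N2CCc3ccccc32)cc1`: 25.7% in this assay

Compound 1 and compound 2 give numbers that lie within the usual scatter of each other, so nothing separates them on this read-out; both sit in the modest range of inhibition at the single concentration tested. For the measured compounds named here, no pair of measured compounds differing in one place is available, so no measured step guides the next change.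

Compound 3 `COc1ccc(N2CCN(C(=S)SCc3ccc(C(=O)Nc4ccccc4N)cc3)CC2)cc1` is to be measured in this assay. It differs from compound 1 as follows: methoxy in place of chloro on an aromatic carbon. With no measured step of this kind in the series, no shift beyond the scatter is expected in either direction. The step from compound 1 to compound 3 is estimated as a number 2.2 percentage points lower from compound 1 to compound 3 (within the scatter) in this assay. Compound 3 is therefore expected to give about 30%, with a range from 15% to 45%.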

Compound 3, a percentage reported as inhibition, at one concentration (the size of the read-out at that concentration, not a potency): 28.1%
Compound 3: middle estimate off by 1.9 percentage points, on the high side, and the stated range covers the measured number.
By their numbers in this assay, from the lowest: compounds 2, 3 and 1 (each within the scatter of the next).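

Swapping 4-chlorophenyl for 4-methoxyphenyl gives the first one-place comparison in the series: a number 4.1 percentage points lower from compound 1 to compound 3 (within the scatter) in this assay. At this aromatic carbon, para to a large group, chloro and methoxy therefore cannot be told apart on this read-out, and the extra heavy atom and hydrogen-bond acceptor that enter with methoxy bring no change that can be read. No measurement is at hand that could account for this step.

On these data alone, whether a carboxylic acid or a dimethylamino group on the same aromatic carbon would move the inhibition beyond the scatter stays open. Also open, as far as these compounds go, is how a plain phenyl with only hydrogen at this place, or a longer chain such as ethoxy, would compare with compound 1 and compound 3 in this assay at the one concentration tested.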